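A few compounds are considered here, and "the series" means these few. Any claim that something is new, unique, unknown or untested is made for them only; others in the source may bear on it.

Measured in an assay on CHO cells for displacement of a labelled ligand from adenosine receptor A1 (Homo sapiens), read by scintillation counting, tested at 10 uM; a lower number here means less inhibition, a higher number more inhibition at the concentration tested (going by the name of the read-out):

compound 1 `Cc1c(-c2ccccc2)sc(N)c1C(=O)c1ccc(Cl)cc1`: 1%
compound 2 `Cc1c(Br)sc(N)c1C(=O)c1ccc(Cl)cc1`: 1%
compound 3 `CC(C)(C)Cc1c(-c2ccoc2)sc(N)c1C(=O)c1ccc(Cl)cc1`: 1%

Compound 3 stands level with compounds 1 and 2 at the digits shown; the gap to its nearest neighbour, compound 1, and to its furthest, compound 2, lies within the scatter in both cases. The shared core carries an amino group, a 4-chlorobenzoyl group and, on the ring carbon beside the sulfur, a group that is varied across the series. Among the measured compounds shown here, the one single-point step measured, no change at the digits printed from compound 1 to compound 2 (within the scatter), is the exchange of phenyl for bromo at that position; it shows no movement. Compound 3, with a furan-3-yl there and a neopentyl group in place of the methyl, is not distinguishable from either of them.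

Compound 4 `COc1cccc(-c2sc(N)c(C(=O)c3ccc(Cl)cc3)c2CC(C)(C)C)c1` differs from compound 3 in one place: 3-methoxyphenyl in place of furan-3-yl on an aromatic carbon. For the measured compounds named here, no measured step exchanges one aryl or heteroaryl group for another at this position, so the only guidance is that every variation tried there so far, including the step from compound 1 to compound 2, has left the read-out flat at the bottom of the scale. The expected step of a number 1 percentage points higher from compound 3 to compound 4 (within the scatter) is therefore none beyond the scatter. Compound 4 is estimated at 2%, within a range from 0% to 12%.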

Compound 4, a percentage reported as inhibition, at one concentration (the size of the read-out at that concentration, not a potency): 1%
The estimate for compound 4 lay 1 percentage points above the measured number, and the stated range covers the measured number.
By their numbers in this assay, from the lowest: compounds 1, 2, 3 and 4 (each within the scatter of the next).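

In this assay, among the compounds shown here, the exchange of furan-3-yl for 3-methoxyphenyl on the aromatic carbon next to the ring sulfur gives no change at the digits printed from compound 3 to compound 4 (within the scatter) and thus extends the flat picture to an exchange of one aromatic ring for another, which no earlier step covered. The step also holds with a neopentyl group on the neighbouring ring atom, and a change from 5 to 8 heavy atoms, with 1 hydrogen-bond acceptor on either side, leaves no trace in this read-out. No measurement shown bears on why the read-out stays flat at this position.

On these data alone, with every compound at the bottom of the scale, it remains open whether any group at this position can lift the read-out, for instance a carboxylic acid or an aminomethyl group on the phenyl ring. Also open, as far as these compounds go, is whether a longer chain in place of the neopentyl group, or an amide in place of the amino group, would give a reading different from the one seen so far.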